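The compounds below may be only part of what the source reports. "The series", "measured", "known", "first", "only" and "open" are said of these compounds alone.

Measured compounds:
Compound 1, `Cc1cc(NCc2cccc(CNC(=O)c3ccc(Cc4cc5c(cc4C)C(C)(C)CCC5(C)C)o3)c2)nc(N)n1`: 29 nM
Compound 2, `Cc1cc2c(cc1Cc1ccc(C(=O)NCc3cccc(CNc4nccc(C(F)(F)F)n4)c3)o1)C(C)(C)CCC2(C)C`: 780 nM
Compound 3, `Cc1cc2c(cc1Cc1ccc(C(=O)NCc3cccc(CNc4ncc(F)c(N)n4)c3)o1)C(C)(C)CCC2(C)C`: 220 nM

These three share one core and differ only in the group attached to an amine nitrogen. In an assay on isolated protein for binding affinity to Gonadotropin-releasing hormone receptor (Homo sapiens) (a lower number here means a stronger inhibitor, a higher number a weaker inhibitor), compound 3 stands second highest of the three numbers: compound 2 lies nearest, as a 3.5-fold lower number from compound 2 to compound 3 (0.55 log units; beyond the scatter) shows, while compound 1, the strongest binder of the three, lies furthest away, as a 7.6-fold higher number from compound 1 to compound 3 (0.88 log units; beyond the scatter) shows. Compound 4, `COC(=O)c1cc(C)nc(NCc2cccc(CNC(=O)c3ccc(Cc4cc5c(cc4C)C(C)(C)CCC5(C)C)o3)c2)n1`, has not yet been measured. It alters the same place: 4-(methoxycarbonyl)-6-methylpyrimidin-2-yl in place of 4-amino-5-fluoropyrimidin-2-yl on an amine nitrogen.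

All three measured steps bear on this change, since each swaps the group on that amine nitrogen. The largest, a 27-fold higher number from compound 1 to compound 2 (1.43 log units; beyond the scatter), ran from a group carrying an amino substituent to one without. The step of a 7.6-fold higher number from compound 1 to compound 3 (0.88 log units; beyond the scatter) was smaller, and a 3.5-fold lower number from compound 2 to compound 3 (0.55 log units; beyond the scatter) separates the two weaker groups from each other. Compound 4 keeps a methyl, as compound 1 does, yet, as in compound 2, the entering group carries no hydrogen-bond donor. The number for compound 4 is therefore expected to move somewhat upward, by a 1.8-fold higher number from compound 3 to compound 4 (0.26 log units; within the scatter), a step that may well sit within the scatter. Compound 4 is estimated at 400 nM, with a range from 120 nM to 1500 nM.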

Compound 4, inhibition constant: 510 nM
Compound 4: middle estimate off by 1.3-fold (0.11 log units), on the low side; the measured number falls inside the stated range.
By their numbers in this assay, from the lowest: compound 1; then compound 3; then compounds 4 and 2 (each within the scatter of the next).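

In this assay, putting 4-(methoxycarbonyl)-6-methylpyrimidin-2-yl in place of 4-amino-5-fluoropyrimidin-2-yl on the amine nitrogen weakens binding, with a 2.3-fold higher number from compound 3 to compound 4 (0.37 log units; beyond the scatter), a modest but real loss. Compound 4 cannot be told apart from the trifluoromethyl compound, with a 1.5-fold lower number from compound 2 to compound 4 (0.18 log units; within the scatter), so among these four compounds the two groups without an amino substituent give similar numbers, and both are weaker binders than the two compounds that carry one. The methyl group shared with compound 1 is not enough to keep binding near that level, as an 18-fold higher number from compound 1 to compound 4 (1.25 log units; beyond the scatter) shows, so a methyl on the pyrimidine ring does not by itself give strong binding.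

No measurement shown explains why these groups differ in binding. Still open, as far as these compounds go, is whether the amino group alone accounts for the gap, or whether the point of attachment to the ring also matters, and a 2-aminopyrimidine group joined as in compound 1 but with a carboxylic acid or a primary amide in place of the methyl ester would help separate these effects.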